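A Sulfonyl Substituent Swap in a Cell-Growth Inhibitor Series

This account rests on a few compounds, and the source may have more. Where it says the series, first, only, none or still open, it means among the compounds named here.

Within the data shown here, all three compounds measured so far were tested in a functional assay on MIA PaCa-2 cells (Homo sapiens) for inhibition, read by MTT assay, with a stated time of 7 days; a lower number here means a stronger inhibitor, a higher number a weaker inhibitor. Compound 1 `CC(C)c1noc(N2CCN(C(=O)[C@@H]3CCCN(S(=O)(=O)c4ccc(S(=O)(=O)C(C)C)cc4)C3)CC2)n1` gives 70 nM in this assay, the lower of the two numbers recorded; the nearest of them belongs to compound 2 `CCN(CC)S(=O)(=O)c1ccc(S(=O)(=O)N2CCC[C@@H](C(=O)N[C@@H]3CCN(C(=O)OC(C)(C)C)C3)C2)cc1`, which gives 200 nM, a gap beyond the usual scatter. Compound 3 `CCOC(=O)N1CCC[C@H](S(=O)(=O)c2ccc(S(=O)(=O)N(CC)CC)cc2)C1` reaches only a limit of the assay, > 30000 nM, and so provides no number; the limit of > 30000 nM in this assay, at which 1 of the 3 values shown sits, records where that limit sits. No two of these compounds differ in a single place, so no measured step connects them.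

Compound 4 `CC(C)c1noc(N2CCN(C(=O)[C@@H]3CCCN(S(=O)(=O)c4ccc(S(=O)(=O)NC(C)(C)C)cc4)C3)CC2)n1` is the next compound to be examined: (tert-butyl)amino in place of isopropyl on a sulfonyl sulfur. Cut one bond further out, the change reads isopropylsulfonyl to (tert-butyl)sulfamoyl; the sulfonyl sulfur keeps its aromatic carbon neighbour and the rest of the molecule is unchanged. Among the measured compounds shown here, with no measured step on which to rest, the expectation is a modest move toward a weaker number, estimated as a 1.6-fold higher number from compound 1 to compound 4 (0.20 log units; within the scatter). Compound 4 is therefore expected to give about 110 nM in this assay, within a range of 35 nM to 350 nM.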

Compound 4, half-maximal inhibitory concentration: 300 nM
Compound 4: the middle estimate sits 2.7-fold (0.44 log units) below what was measured; the range from low to high includes it.
By their numbers in this assay, from the lowest: compound 1; then compounds 2 and 4 (each within the scatter of the next). At a limit, above all of these: compound 3.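

In this assay, among these compounds, the first single-place step in this set falls on a sulfonyl sulfur whose other neighbour is an aromatic carbon: (tert-butyl)amino in place of isopropyl gives a 4.3-fold higher number from compound 1 to compound 4 (0.63 log units; beyond the scatter) at this position. The number therefore responds to what sits on this sulfur, yet compound 4 still gives a measured number rather than a limit. Nothing shown here accounts for the size of this step.

Going by these compounds, whether the nitrogen with its hydrogen or the larger tert-butyl carries the change stays open, and a plain amino group or a methyl on the same sulfur would begin to separate the two. On these data alone, how a cyclic amine such as morpholine would fare at this position also remains open, as does whether the step holds on other parts of the series.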